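Phenyl to Isopropyl on the Five-Membered Core

The source may report more compounds than this note shows. Statements on the series, on what has been measured and on what is new or still open speak of the compounds shown alone.

Compound 1, `CCC(C)C(NC(=O)n1nnc2ccccc21)C(=O)NC(c1ccccc1)c1ccccc1`: > 100000 nM, a limit of the assay.
Compound 2, `O=C1NC(c2ccccc2)C(=O)N1C1CCCC1`: 22000 nM.
Compound 3, `CCC(C)C(NC(=O)NO)C(=O)NC1CCCC1`: > 100000 nM, a limit of the assay.

For the measured compounds named here, in a functional assay on MCF7 cells (Homo sapiens) for inhibition (a higher number here means a weaker inhibitor, a lower number a stronger inhibitor), compound 2 gives the only number among the three; the other two sit at the limit of > 100000 nM in this assay, at which 2 of the 3 values shown sit. Going by the values given here, no step between measured compounds that differ in one place is available, so the size of any change must be judged from compound 2 alone.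

Compound 4, `CC(C)C1NC(=O)N(C2CCCC2)C1=O`, differs from compound 2 by isopropyl in place of phenyl on a saturated ring carbon. A loss of potency beyond the scatter is expected, with the step of a 2.7-fold higher number from compound 2 to compound 4 (0.44 log units; beyond the scatter) estimated for this change. Compound 4 is therefore expected at 60000 nM, in a range from 20000 nM to 150000 nM, with a real chance that only a limit is returned.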

Compound 4, half-maximal inhibitory concentration: > 100000 nM
Compound 4: no number, only a limit; the forecaster's own chance of this, stated with the estimate: 35%; middle value at least 1.6-fold (0.22 log units) away from the limit.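

On the saturated ring carbon of the shared core, isopropyl in place of phenyl gives an at least 4.5-fold higher number from compound 2 to compound 4 (0.65 log units; beyond the scatter) in this assay. For the compounds shown here, this is the first readable step at this position, and it shows that the measurable inhibition of compound 2 is lost with this single change. The step is only a lower bound, and its full size cannot be read: the limit of > 100000 nM in this assay, at which 3 of the 4 values shown sit.

The compounds shown leave open whether a benzyl group or a pyridine ring on this carbon would give a number in this assay. They also leave open whether a longer chain would do so.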